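Swapping Amino for Nitro: What Cytotoxicity to Expect

This account rests on a few compounds, and the source may have more. Where it says the series, first, only, none or still open, it means among the compounds named here.

Measured so far in an ADME assay on Vero cells (Chlorocebus sabaeus) for cytotoxicity; on this read-out lower numbers stand for higher toxicity in this test and higher numbers for lower toxicity in this test:
Compound 1 `COc1ccc(-c2nc3cc(C(F)(F)F)ccc3[nH]2)c(N)c1` gives 50000 nM.
Compound 2 `Cn1c(-c2ccc(NC(=O)CN3CCCCC3)cc2)nc2cc(C(F)(F)F)ccc21` gives > 100000 nM, a limit of the assay rather than a number.
Compound 3 `CCN(CC)CC(=O)Nc1ccc(-c2nc3cc(C(F)(F)F)ccc3[nH]2)cc1` gives 24000 nM.

Among the compounds with values here, only two of the three values are numbers, and compound 1 holds the higher of them, which in this test means the lower toxicity; compound 3 sits one step lower, and that step lies beyond the usual scatter. The value of compound 2 is a limit, and it stands at the limit of > 100000 nM in this assay, at which 1 of the 3 values shown sits.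

Compound 4 `COc1ccc(-c2nc3cc(C(F)(F)F)ccc3[nH]2)c([N+](=O)[O-])c1` has not yet been measured. It differs from compound 1 in one place: nitro in place of amino on an aromatic carbon. Within the data shown here, no pair of measured compounds shows this change, so there is no measured step to lean on. The three values here sit within a narrow band, so for this change a small move in either direction, or none beyond the scatter, is the expectation. For compound 4 the expected value in this assay is 40000 nM, with a range from 15000 nM to 100000 nM. That estimate corresponds to a step of a 1.3-fold lower number from compound 1 to compound 4 (0.10 log units; within the scatter), essentially no move beyond the scatter.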

Compound 4, half-maximal cytotoxic concentration: 20000 nM
Beside the measured number, compound 4's estimate is 2.0-fold (0.30 log units) above it, and the stated range covers the measured number.
By their numbers in this assay, from the lowest: compounds 4 and 3 (each within the scatter of the next); then compound 1. At a limit, above all of these: compound 2.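

In this assay, nitro in place of amino on an aromatic carbon, ortho to a large group, gives the first measured step for a change in one place among these compounds: a 2.5-fold lower number from compound 1 to compound 4 (0.40 log units; beyond the scatter). The step is modest, yet it shows that the group on this ring carbon can move the read-out beyond the usual scatter, and that this swap moves it towards higher toxicity in this test. Within the data shown here, the measurements show the size and direction of this move, but nothing given here explains why it happens, and the one limit value shown has no bearing on that question.

On these data alone, this is a single swap at a single position, so it remains open how the read-out would respond to another group on the same carbon, such as a hydroxyl group, a carboxylic acid or a nitrile, and whether such a group would land nearer to compound 1 or to compound 4. As far as these compounds go, it is also open whether nitro in place of amino would give a step of similar size and direction elsewhere on this ring or on a different core.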